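This account rests on a few compounds, and the source may have more. Where it says the series, first, only, none or still open, it means among the compounds named here.

Measured so far in a functional assay on PC-3 cells (Homo sapiens) for cytotoxicity, read by MTT assay, with a stated time of 72 h; on this read-out higher numbers stand for weaker inhibition and lower numbers for stronger inhibition:
compound 1 `COc1ccc(S(=O)(=O)c2nc3ccccc3nc2Nc2cccc(N)c2)cc1`: 8600 nM
compound 2 `COc1ccc(S(=O)(=O)c2nc3ccccc3nc2Nc2ccc(F)cc2)cc1`: 2200 nM

Compound 1 has the higher of the two numbers in this assay; the difference to compound 2 is a 3.9-fold lower number from compound 1 to compound 2 (0.59 log units; beyond the scatter), which concerns the group on the nitrogen, not the part changed here. Compound 3 `Nc1cccc(Nc2nc3ccccc3nc2S(=O)(=O)c2ccc(Br)cc2)c1` differs from compound 1 by bromo in place of methoxy on an aromatic carbon. Within the data shown here, no measured step bears on this exchange, so there is no basis for expecting a shift beyond the scatter, and the step in this assay is estimated at a 1.2-fold lower number from compound 1 to compound 3 (0.09 log units; within the scatter). Compound 3 is expected near 7000 nM, between 2000 nM and 25000 nM.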

Compound 3, half-maximal inhibitory concentration: 9010 nM
Compound 3: middle estimate off by 1.3-fold (0.11 log units), on the low side; the measured number falls inside the stated range.
By their numbers in this assay, from the lowest: compound 2; then compounds 1 and 3 (each within the scatter of the next).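

In this assay, bromo in place of methoxy on the aromatic carbon gives a 1.0-fold higher number from compound 1 to compound 3 (0.02 log units; within the scatter), so the two groups cannot be told apart at this position, although the methoxy takes its hydrogen-bond acceptor with it. The earlier step concerned the group on the nitrogen and moved the number beyond the scatter; this exchange on the other aromatic ring does not. No evidence on this result is available.

Going by these compounds, it remains open whether a carboxylic acid or an amine at this position would leave the number within the scatter. On these data alone, it is also open whether bromo would do so alongside the 4-fluorophenyl group of compound 2.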